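The source may hold more compounds than are shown below. What is called first, only, known or untested is meant among the compounds shown, and "the series" means these compounds.

Series notes. Compound 1 `O=[N+]([O-])c1ccc([C@@H]2OC[C@H]3O[C@@H](c4ccccc4)[C@H](O)[C@@H](O)[C@@H]3O2)cc1`, compound 2 `C=CCCCO[C@@H]1[C@@H](OCCCC=C)[C@H](c2ccccc2)O[C@@H]2CO[C@@H](c3ccccc3)O[C@@H]12` and compound 3 `C#CCO[C@@H]1[C@@H](OCC#C)[C@H](c2ccccc2)O[C@@H]2CO[C@@H](c3ccccc3)O[C@@H]12` share one core. In a functional assay on HEL cells (Homo sapiens) for cytotoxicity (a lower number here means that less compound is tolerated, a higher number that more compound is tolerated), compound 1 gives 50 ug/mL, while in this assay compound 2 gives "not determined" (no result reported). In this assay compound 3 gives 40 ug/mL; set beside compound 1, this number lies within the scatter, so the two cannot be told apart on the figures to hand. Compound 4 `C#CCO[C@@H]1[C@@H](OCC#C)[C@H](Cc2ccccc2)O[C@@H]2CO[C@@H](c3ccccc3)O[C@@H]12` is the next entry. It differs from compound 3 by benzyl in place of phenyl on a saturated ring carbon. For the measured compounds named here, no measured pair in the set carries a comparable change, so there is nothing to anchor a direction; the expectation is a step no larger than the scatter, in either sense. Compound 4 is expected to give about 40 ug/mL, with a range of 20 ug/mL to 80 ug/mL. The estimated step of no change at the digits printed from compound 3 to compound 4 (within the scatter) is thus one of little size.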

Compound 4, minimum cytotoxic concentration: 40 ug/mL
Compound 4: the middle estimate sits on the measured number at the digits printed; the range from low to high includes it.
By their numbers in this assay, from the lowest: compounds 3, 4 and 1 (each within the scatter of the next).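

Benzyl in place of phenyl on this saturated ring carbon, next to the ring oxygen, gives no change at the digits printed from compound 3 to compound 4 (within the scatter) in this assay. For the compounds shown here, this is the first measured change at this position, and on these figures the two groups cannot be told apart. Nothing on hand offers an explanation for this result. As far as these compounds go, whether an amine, a carboxylic acid or a longer chain carrying the phenyl at this ring carbon would read differently in this assay remains open. The same holds for a substituted benzyl, such as 4-nitrobenzyl.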